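The source may report more compounds than this note shows. Statements on the series, on what has been measured and on what is new or still open speak of the compounds shown alone.

Measured so far:
compound 1 `CCCc1cc(N)c2cc(NC(=O)/C=C/c3ccc(O)cc3)ccc2n1` gives 1100 nM;
compound 2 `CCC(C)c1cc(N)c2cc(NC(=O)/C=C/c3ccc(C(F)(F)F)cc3)ccc2n1` gives 0.3 nM;
compound 3 `Cc1cc(N)c2cc(NC(=O)/C=C/c3ccc(C(F)(F)F)cc3)ccc2n1` gives 8 nM.

All three numbers come from an assay on isolated protein for displacement of a labelled ligand from melanin-concentrating hormone receptor 1 (Homo sapiens); on this read-out higher numbers stand for weaker inhibition and lower numbers for stronger inhibition. Compound 3 stands second highest of the three: compound 2 gives the lower number, and compound 1 gives a clearly higher one. Within the data shown here, the only step measured in one place runs from compound 2 to compound 3, where methyl replaced sec-butyl on an aromatic carbon, and it gave a 27-fold higher number from compound 2 to compound 3 (1.43 log units; beyond the scatter). Compound 4 `Nc1cc(C2CCCC2)nc2ccc(NC(=O)/C=C/c3ccc(C(F)(F)F)cc3)cc12` differs from compound 3 by cyclopentyl in place of methyl on an aromatic carbon. Cyclopentyl enters where the methyl sat, with five carbons in a ring, which in size recalls the sec-butyl of compound 2 more than the methyl of compound 3. The step from compound 2 to compound 3 therefore bears on this one, in reverse: a large step toward lower numbers is expected, roughly undoing that step, and estimated as a 16-fold lower number from compound 3 to compound 4 (1.20 log units; beyond the scatter). Compound 4 is thus estimated at 0.5 nM, within a range from 0.1 nM to 3 nM.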

Compound 4, half-maximal inhibitory concentration: 0.8 nM
Compound 4: the middle estimate sits 1.6-fold (0.20 log units) below what was measured, and the stated range covers the measured number.
By their numbers in this assay, from the lowest: compound 2; then compound 4; then compound 3; then compound 1.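

Compound 2 and compound 3 showed only that sec-butyl at this aromatic carbon, next to the ring nitrogen, gives a much lower number than methyl. In this assay the new result adds that an open branched chain is not needed for such a drop: closing the carbons into a cyclopentyl ring gives a 10-fold lower number from compound 3 to compound 4 (1.00 log units; beyond the scatter) in exchange for methyl. The two groups are still not interchangeable, since there is a 2.7-fold higher number from compound 2 to compound 4 (0.43 log units; beyond the scatter) when cyclopentyl replaces sec-butyl, a modest step but beyond the scatter. Nothing available here explains the difference between these groups.

As far as these compounds go, what a cyclohexyl or phenyl ring would give at this carbon remains open. So does the effect of a longer straight chain, or of a chain ending in an amine.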